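The compounds below may be only part of what the source reports. "The series", "measured", "known", "first", "only" and "open" are said of these compounds alone.

Measured so far:
- compound 1, `Cn1nc2c(=O)n(CC3(O)CCN(Cc4ccc(-c5ccco5)cc4Cl)CC3)cnc2c1-c1ccc(C(N)=O)cc1`: 80.8 nM in an assay on isolated protein for inhibition of ubiquitin carboxyl-terminal hydrolase 7 (Homo sapiens), with stated times of 30 min and 2 h; on this read-out higher numbers stand for weaker inhibition and lower numbers for stronger inhibition
- compound 2, `CN(C)Cc1ccc(-c2c3ncn(CC4(O)CCN(Cc5ccc(-c6ccco6)cc5Cl)CC4)c(=O)c3nn2C)cc1`: 131 nM in this assay

Among these two numbers compound 2 has the higher one, though the step of a 1.6-fold higher number from compound 1 to compound 2 (0.21 log units; within the scatter) lies within the scatter, so the two compounds cannot be separated. Compound 3, `Cn1nc2c(=O)n(CC3(O)CCN(Cc4ccc(-c5ccco5)cc4Cl)CC3)cnc2c1-c1ccc(C(F)(F)F)cc1`, is not yet measured. It differs from compound 2 by trifluoromethyl in place of (dimethylamino)methyl on an aromatic carbon. Going by the values given here, the one step at this position, a 1.6-fold higher number from compound 1 to compound 2 (0.21 log units; within the scatter), was small, which suggests a change at this place matters little. The expected step is therefore a 1.5-fold higher number from compound 2 to compound 3 (0.18 log units; within the scatter). Compound 3 is estimated at 200 nM, with a range from 60 nM to 700 nM.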

Compound 3, half-maximal inhibitory concentration: 530 nM
The estimate for compound 3 lay 2.7-fold (0.42 log units) below the measured number, within the range that was stated.
By their numbers in this assay, from the lowest: compounds 1 and 2 (each within the scatter of the next); then compound 3.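

In this assay this position turns out not to be indifferent: trifluoromethyl brings a 4.0-fold higher number from compound 2 to compound 3 (0.61 log units; beyond the scatter) and also a 6.6-fold higher number from compound 1 to compound 3 (0.82 log units; beyond the scatter) and both steps lie beyond the scatter. Carbamoyl and (dimethylamino)methyl could not be separated from each other, yet each stands apart from trifluoromethyl. Nothing measured here explains this difference. Still open, as far as these compounds go, is where a carboxylic acid, a methoxy group or a plain hydrogen at this place would fall: with compound 1 and compound 2, or with compound 3.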